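The compounds below may be only part of what the source reports. "The series", "measured", "known", "first", "only" and "open" are said of these compounds alone.

Working notes on the series. In an assay on isolated protein (Oryctolagus cuniculus) for inhibition of Calpain-2 catalytic subunit (Homo sapiens) (a higher number here means a weaker inhibitor, a lower number a stronger inhibitor), compound 1 `CCC(NC(=O)C(CC(C)C)NC(=O)OCc1ccccc1)C(=O)C(=O)NCc1ccccc1` gives 350 nM, compound 2 `CCC(NC(=O)C(CC(C)C)NC(=O)OCc1ccccc1)C(=O)C(=O)NCc1cc(OC)cc(OC)c1` gives 22 nM and compound 3 `CCC(NC(=O)C(CC(C)C)NC(=O)OCc1ccccc1)C(=O)C(=O)NCc1ccc2ccccc2n1` gives 600 nM. Compound 3 has the highest number of the three; the steps of a 1.7-fold higher number from compound 1 to compound 3 (0.23 log units; within the scatter) and a 27-fold higher number from compound 2 to compound 3 (1.44 log units; beyond the scatter) set its distances to the others. Compound 4 `CCC(NC(=O)C(CC(C)C)NC(=O)OCc1ccccc1)C(=O)C(=O)NCCCN1CCCc2ccccc21` differs from compound 3 by 2-(1,2,3,4-tetrahydroquinolin-1-yl)ethyl in place of quinolin-2-yl on a saturated chain carbon bound to an amide-type nitrogen. Within the data shown here, both measured steps at this carbon bear on the change: a 1.7-fold higher number from compound 1 to compound 3 (0.23 log units; within the scatter) was small, while a 27-fold higher number from compound 2 to compound 3 (1.44 log units; beyond the scatter) was large, so this position can move the number a great deal, yet no measured step covers a non-aromatic ring on a chain here, and the direction cannot be read off. The expected step is therefore a 1.5-fold lower number from compound 3 to compound 4 (0.18 log units; within the scatter). Compound 4 is estimated at 400 nM, within 120 nM to 1300 nM.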

Compound 4, inhibition constant: 200 nM
Compound 4: middle estimate off by 2.0-fold (0.30 log units), on the high side; the range from low to high includes it.
By their numbers in this assay, from the lowest: compound 2; then compounds 4, 1 and 3 (each within the scatter of the next, the first and the last beyond it).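

In this assay, a non-aromatic ring on a chain at this carbon is compatible with a number in the range of the aromatic groups: the change gives a 3.0-fold lower number from compound 3 to compound 4 (0.48 log units; beyond the scatter) and, against phenyl, a 1.8-fold lower number from compound 1 to compound 4 (0.24 log units; within the scatter), which does not separate the two groups. It does not match 3,5-dimethoxyphenyl, with a 9.1-fold higher number from compound 2 to compound 4 (0.96 log units; beyond the scatter) setting the gap. No evidence at hand accounts for these steps.

On these data alone, whether a longer chain would keep or lose this gain remains open. So does whether an open-chain amine such as dimethylamino could replace the ring.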